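A few compounds are considered here, and "the series" means these few. Any claim that something is new, unique, unknown or untested is made for them only; others in the source may bear on it.

Three compounds of one series have numbers in a functional assay on CHO cells with adenosine receptor A1 (Homo sapiens) as the target, read by cAMP accumulation and immunoassay, with a stated time of 6 min, tested at 1 uM; a lower number here means a stronger effect, a higher number a weaker effect of the compound at the concentration tested. Compound 1 `COc1ccc(N2CCN(Cc3csc(N)c3C(=O)c3ccc(Cl)cc3)CC2)cc1` gives -15%. Compound 2 `Nc1scc(CN2CCN(c3ccc([N+](=O)[O-])cc3)CC2)c1C(=O)c1ccc(Cl)cc1` gives -8.3%. Compound 3 `Nc1scc(CN2CCN(c3ccccc3Cl)CC2)c1C(=O)c1ccc(Cl)cc1` gives -5.2%. Compound 2 stands second highest of the three; its nearest neighbour is compound 3, with a number 3.1 percentage points higher from compound 2 to compound 3 (within the scatter), and the furthest is compound 1, with a number 6.7 percentage points higher from compound 1 to compound 2 (within the scatter). Compound 4 `Nc1scc(CN2CCN(c3cc(Cl)ccc3Cl)CC2)c1C(=O)c1ccc(Cl)cc1` is not yet measured; it differs from compound 2 in one place: 2,5-dichlorophenyl in place of 4-nitrophenyl on an amine nitrogen in a ring. Two measured steps also exchange the group on the amine nitrogen in a ring: a number 9.8 percentage points higher from compound 1 to compound 3 (within the scatter) and a number 3.1 percentage points higher from compound 2 to compound 3 (within the scatter). Both stay within the scatter, as does a number 6.7 percentage points higher from compound 1 to compound 2 (within the scatter). Going by the values given here, no step in this assay has so far moved a number beyond the scatter, so for compound 4 no step beyond the scatter is expected in either direction; the expected step is a number 2.3 percentage points higher from compound 2 to compound 4 (within the scatter). Compound 4 is therefore estimated at -6%, with a range from -20% to 8%.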

Compound 4, a percentage reported as activity, at one concentration (the size of the read-out at that concentration, not a potency): -42%
For compound 4 the middle estimate is 36 percentage points above the measured one; the measured number lies below the stated range.
By their numbers in this assay, from the lowest: compound 4; then compounds 1, 2 and 3 (each within the scatter of the next).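

In this assay, going by these compounds alone, the group on the amine nitrogen in a ring had so far given no step beyond the scatter, yet 2,5-dichlorophenyl does give one, with a number 33.7 percentage points lower from compound 2 to compound 4 (beyond the scatter) against 4-nitrophenyl and a number 27 percentage points lower from compound 1 to compound 4 (beyond the scatter) against 4-methoxyphenyl. The clearest comparison is the one that adds a single chloro in place of hydrogen on an aromatic carbon, with a number 36.8 percentage points lower from compound 3 to compound 4 (beyond the scatter) for that change alone. The 2-chlorophenyl group of compound 3 therefore does not carry this shift by itself, and the second chloro is what separates the two compounds. The compounds shown offer nothing that accounts for the step.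

As far as these compounds go, whether the step depends on chloro itself or on where the two chloro groups sit in 2,5-dichlorophenyl stays open, and methyl or bromo in place of both chloro groups of 2,5-dichlorophenyl would bear on that. These numbers come from one concentration and give the size of the read-out, not a potency.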